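The source may hold more compounds than are shown below. What is called first, only, known or untested is meant among the compounds shown, and "the series" means these compounds.

The measured compounds:
compound 1, `CC1=C(/C=C/C(=O)/C=C/c2ccc(C#N)cc2)C(C)(C)CCC1`, which in a functional assay on IMR-32 cells (Homo sapiens) for cytotoxicity, read by sulforhodamine B assay, with a stated time of 48 h (a lower number here means a stronger inhibitor, a higher number a weaker inhibitor), gives 23400 nM
compound 2, `CC1=C(/C=C/C(=O)/C=C/c2ccc(C)cc2)C(C)(C)CCC1`, which in this assay gives 19200 nM

Among the measured compounds shown here, compound 2 holds the lowest of the two numbers so far, but its nearest neighbour is compound 1, and the step of a 1.2-fold lower number from compound 1 to compound 2 (0.09 log units; within the scatter) lies within the scatter, so the two compounds cannot be told apart on these numbers.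

Compound 3, `CC1=C(/C=C/C(=O)/C=C/c2ccccc2F)C(C)(C)CCC1`, is the next compound to be measured in this assay. It differs from compound 2 in one place: 2-fluorophenyl in place of 4-methylphenyl on a double-bonded chain carbon bound to a double-bonded chain carbon.

For the measured compounds named here, only one measured step exists, the one from compound 1 to compound 2, which exchanged cyano for methyl on an aromatic carbon and stayed within the scatter. Going by the values given here, that step does not touch the change now made, which moves from a 4-methylphenyl to a 2-fluorophenyl, so no measured step bears directly on it. With nothing in the data pointing either way, the step from compound 2 to compound 3 is expected to be a 1.0-fold higher number from compound 2 to compound 3 (0.02 log units; within the scatter), not beyond the scatter. Compound 3 is therefore estimated at 20000 nM, with a range from 8000 nM to 50000 nM.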

Compound 3, half-maximal inhibitory concentration: 15600 nM
The estimate for compound 3 lay 1.3-fold (0.11 log units) above the measured number; the measured number falls inside the stated range.
By their numbers in this assay, from the lowest: compounds 3, 2 and 1 (each within the scatter of the next).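

In this assay, putting 2-fluorophenyl in place of 4-methylphenyl on a double-bonded chain carbon bound to a double-bonded chain carbon gives a 1.2-fold lower number from compound 2 to compound 3 (0.09 log units; within the scatter) and so cannot be told apart from the scatter. The earlier step exchanged only cyano for methyl on an aromatic carbon, whereas this one replaces the whole 4-methylphenyl group, and even this broader exchange at this place yields no difference that the numbers can resolve. No measurement offered here bears on why the exchange leaves the number within the scatter.

The exchange alters both the group on the ring and where it sits, so the two compounds cannot separate these changes, and a 4-fluorophenyl or 2-methylphenyl group at the same place would be needed to do so. As far as these compounds go, it also remains open whether any group at this place can move the number beyond the scatter, for example a phenyl ring carrying an amine or a carboxylic acid, or a longer chain in place of the aromatic ring.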